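From isopropyl to sec-butyl on the shared core

This account rests on a few compounds, and the source may have more. Where it says the series, first, only, none or still open, it means among the compounds named here.

In an ADME assay on RAW264.7 cells (Mus musculus) for cytotoxicity, read by MTT assay, with a stated time of 24 h (on this read-out lower numbers stand for higher toxicity in this test and higher numbers for lower toxicity in this test), compound 1 (`CC/C=C\C[C@H]1C(=O)C=C[C@H]1CC(=O)Oc1ccc(O)cc1`) gives 49 uM and compound 2 (`CC/C=C\C[C@H]1C(=O)C=C[C@H]1CC(=O)OC(C)C`) gives 58 uM. With only these two numbers available, compound 2 stands within the scatter of compound 1.

The next entry is compound 3 (`CC/C=C\C[C@H]1C(=O)C=C[C@H]1CC(=O)OC(C)CC`), not yet measured in this assay. Its difference from compound 2 is methyl in place of hydrogen on a saturated chain carbon, two bonds along the chain from an oxygen next to a carbonyl group. In words, this is methyl in place of hydrogen on a saturated chain carbon, two bonds along the chain from an oxygen next to a carbonyl group, which turns isopropyl into sec-butyl.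

Going by the values given here, one measured step bears on this change: a 1.2-fold higher number from compound 1 to compound 2 (0.07 log units; within the scatter). That step exchanged 4-hydroxyphenyl for isopropyl on an oxygen next to a carbonyl group. Among the compounds with values here, no measured pair covers the addition of a methyl on the chain itself, so the evidence is thin. On this single step, no change beyond the scatter is expected. The expected step is a 1.1-fold lower number from compound 2 to compound 3 (0.05 log units; within the scatter). For compound 3, the estimated value is 52 uM, with an expected range of 28 uM to 95 uM.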

Compound 3, half-maximal toxic concentration: 53 uM
For compound 3 the middle estimate is 1.0-fold (0.01 log units) below the measured one, within the range that was stated.
By their numbers in this assay, from the lowest: compounds 1, 3 and 2 (each within the scatter of the next).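

In this assay, methyl in place of hydrogen on a saturated chain carbon, two bonds along the chain from an oxygen next to a carbonyl group, gives a 1.1-fold lower number from compound 2 to compound 3 (0.04 log units; within the scatter), so this position takes the added methyl with no step beyond the scatter. The exchange of 4-hydroxyphenyl for sec-butyl on an oxygen next to a carbonyl group gives a 1.1-fold higher number from compound 1 to compound 3 (0.03 log units; within the scatter), which means that 4-hydroxyphenyl, isopropyl and sec-butyl cannot be told apart on this read-out, and all three compounds lie within the scatter of one another. Nothing at hand explains why the three numbers stay together.

As far as these compounds go, whether a longer chain, an amine or a carboxylic acid on this same oxygen would still fall within the scatter of compound 2 remains open. From the compounds shown here alone, all three compounds also keep the shared core unchanged, so the effect of a change on the core itself on the half-maximal toxic concentration remains open too.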